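From allyloxy to fluoro on a shared core

The compounds below may be only part of what the source reports. "The series", "measured", "known", "first", "only" and "open" are said of these compounds alone.

Compound 1 `C=CCOc1cc(C2=C(c3cc(OC)c(OC)c(OC)c3)C(=O)C(O)C2)ccc1OC` was tested in an ADME assay on ECV-304 cells (Homo sapiens) for cytotoxicity, read by MTT assay, with a stated time of 72 h; on this read-out higher numbers stand for weaker inhibition and lower numbers for stronger inhibition. Compound 1 gives > 100 ug/mL, which is a limit of the assay and not a number. Compound 2 `COc1ccc(C2=C(c3cc(OC)c(OC)c(OC)c3)CC(O)C2=O)cc1[N+](=O)[O-]` gives > 100 ug/mL, which is also a limit. Compound 3 `COc1cc(C2=C(c3cc(C)c(OC)c(C)c3)C(OC(C)=O)CC2=O)cc(OC)c1OC` gives > 100 ug/mL, again a limit. Compound 1 therefore stands with the other two at the limit of > 100 ug/mL in this assay, at which 3 of the 3 values shown sit, and no measured number sets any of them apart.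

Compound 4 `COc1ccc(C2=C(c3cc(OC)c(OC)c(OC)c3)C(=O)C(O)C2)cc1F` keeps the core of compound 1 but carries fluoro in place of allyloxy on an aromatic carbon, ortho to a methoxy group and meta to a large group (fluoro in place of allyloxy on an aromatic carbon). Going by the values given here, no step between measured compounds is available as a guide, so this assay is expected to show no change beyond the usual scatter, although a real gain in inhibition cannot be ruled out. The expected change is a number no higher from compound 1 to compound 4 (the limit leaves the size open). Compound 4 is estimated at 100 ug/mL, with an expected range from 20 ug/mL to 150 ug/mL.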

Compound 4, half-maximal inhibitory concentration: 19.5 ug/mL
Estimate against measurement, compound 4: 5.1-fold (0.71 log units) above; the measured number lies below the stated range.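

In this assay, putting fluoro in place of allyloxy on this aromatic carbon, ortho to a methoxy group, gives an at least 5.1-fold lower number from compound 1 to compound 4 (0.70 log units; beyond the scatter). Compound 1 gives > 100 ug/mL, which is a limit and not a number, so the full size of this step cannot be read. This single change is enough to give the shared core a measured number, which sets compound 4 apart from the other compounds shown: the limit of > 100 ug/mL in this assay, at which 3 of the 4 values shown sit.

From the compounds shown here alone, whether the gain comes from fluoro itself or from the loss of allyloxy stays open, and a chloro group, a hydroxyl group or a plain hydrogen on this carbon would help to separate the two. One pair also cannot show whether fluoro would have the same effect on a different core.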